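Replacing the urea tail of compound 3 with a pyrrolidinone ring

The source may report more compounds than this note shows. Statements on the series, on what has been measured and on what is new or still open speak of the compounds shown alone.

Measured compounds:
- compound 1 `O=C(NCc1ccc(C(=O)N2CCCCc3ccccc32)c(F)c1)Nc1c(F)cccc1F`: 180 nM
- compound 2 `O=C(NCc1ccc(C(=O)N2CCCCc3ccccc32)c(Cl)c1)Nc1c(F)cccc1F`: 40 nM
- compound 3 `Cc1cc(C(=O)N2CCCCc3ccccc32)ccc1CNC(=O)NCC(N)=O`: 210 nM

In a functional assay on HEK293 cells for agonist activity at Vasopressin V2 receptor (Homo sapiens), read by a luciferase reporter and cAMP accumulation (a higher number here means that more compound is needed for the effect, a lower number that less compound is needed), compound 3 gives the highest of the three numbers. Compound 1 is within the scatter of it, while compound 2 stands beyond the scatter, with a lower number. Among the measured compounds shown here, the one measured step, a 4.5-fold lower number from compound 1 to compound 2 (0.65 log units; beyond the scatter), concerns a halogen swap on an aromatic carbon and does not touch the part of the molecule that changes here.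

Compound 4 `Cc1cc(C(=O)N2CCCCc3ccccc32)ccc1CNC(=O)N1CC(=O)C[C@H]1C(=O)N(C)C` differs from compound 3 in one place: 2-(dimethylcarbamoyl)-4-oxopyrrolidin-1-yl in place of (carbamoylmethyl)amino on a carbonyl carbon. For the measured compounds named here, no measured pair shows what this kind of change does in this assay, so there is no step to lean on, and the change is larger than the halogen swap in both atoms and shape.

With nothing to point in either direction, compound 4 is expected to stay near compound 3, with a step of about a 1.1-fold lower number from compound 3 to compound 4 (0.02 log units; within the scatter) and a wide range. The estimate for compound 4 is 200 nM, between 50 nM and 800 nM.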

Compound 4, half-maximal effective concentration: 27 nM
For compound 4 the middle estimate is 7.4-fold (0.87 log units) above the measured one, and the stated range ends above it.
By their numbers in this assay, from the lowest: compounds 4 and 2 (each within the scatter of the next); then compounds 1 and 3 (each within the scatter of the next).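

In this assay, the tail on this carbonyl carbon tolerates much more than a small edit: 2-(dimethylcarbamoyl)-4-oxopyrrolidin-1-yl in place of (carbamoylmethyl)amino gives a 7.8-fold lower number from compound 3 to compound 4 (0.89 log units; beyond the scatter), even though the entering group is larger, holds a five-membered ring and one defined stereocentre, and has no hydrogen-bond donors. Among the compounds shown here, the earlier measured step concerned only a halogen on an aromatic carbon, so this is the first measured sign that changing this tail can shift the number beyond the scatter. Nothing measured here accounts for the shift.

The ring, the oxo group and the dimethylcarbamoyl group arrive together in one change, and the compounds shown leave open which of them carries the step. Also open, on these data alone, is what a plain pyrrolidine ring, a carboxylic acid in place of the dimethylcarbamoyl group, or the opposite stereocentre would give.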